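The source may report more compounds than this note shows. Statements on the series, on what has been measured and on what is new or still open speak of the compounds shown alone.

Values measured in a functional assay on NCI-H460 cells (Homo sapiens) for cytotoxicity, read by MTT assay, with a stated time of 96 h (on this read-out lower numbers stand for stronger inhibition and higher numbers for weaker inhibition), are as follows.

- Compound 1 `COc1ncc(-c2cc(OCC3CCOCC3)c3nc(N)nc(C)c3c2)cc1NS(=O)(=O)c1ccc(F)cc1F` gives 21 nM
- Compound 2 `CNc1nc(C)c2cc(-c3cnc(OC)c(NS(=O)(=O)c4ccc(F)cc4F)c3)cc(OCC3CCOC3)c2n1` gives 310 nM
- Compound 3 `CNc1nc(C)c2cc(-c3cnc(OC)c(NS(=O)(=O)c4ccc(F)cc4F)c3)cc(OC3CCOC(C)(C)C3)c2n1` gives 250 nM

Compound 3, at 250 nM, sits level with compound 2, at 310 nM, within the usual scatter. Compound 1, at 21 nM, has a clearly lower number than either, well beyond that scatter.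

The next molecule, compound 4 `CNc1nc(C)c2cc(-c3cnc(OC)c(NS(=O)(=O)c4ccc(F)cc4F)c3)cc(OCC3CCOCC3)c2n1`, has not yet been measured. It changes compound 3 in one place, on an oxygen on an aromatic ring: (oxan-4-yl)methyl in place of 2,2-dimethyloxan-4-yl on an oxygen on an aromatic ring. For the measured compounds named here, only one measured step concerns this same oxygen, a 1.2-fold lower number from compound 2 to compound 3 (0.09 log units; within the scatter), and it stays within the scatter. That single swap suggests that exchanging these groups need not move the number much.

Compound 1 also carries (oxan-4-yl)methyl on that oxygen, and its value of 21 nM leans the expectation slightly downward. However, its core differs from the core shared by compounds 2, 3 and 4, so it counts for little. A modest move toward a lower number in this assay is therefore expected, not beyond the scatter, with an estimated size of a 1.7-fold lower number from compound 3 to compound 4 (0.22 log units; within the scatter). For compound 4 the estimated value is 150 nM, with an expected range from 50 nM to 400 nM.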

Compound 4, half-maximal inhibitory concentration: 400 nM
Compound 4: middle estimate off by 2.7-fold (0.43 log units), on the low side, and the stated range covers the measured number.
By their numbers in this assay, from the lowest: compound 1; then compounds 3, 2 and 4 (each within the scatter of the next).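

In this assay, the oxygen on the aromatic ring accepts three different groups with no change beyond the scatter: replacing 2,2-dimethyloxan-4-yl with (oxan-4-yl)methyl gives a 1.6-fold higher number from compound 3 to compound 4 (0.20 log units; within the scatter), and replacing oxolan-3-yl with oxan-4-yl on the saturated chain carbon gives a 1.3-fold higher number from compound 2 to compound 4 (0.11 log units; within the scatter). So far, then, neither this exchange nor the change in ring size separates these compounds, although three compounds are a small sample. The larger finding lies elsewhere: compound 1 and compound 4 differ in one place only, so the large gap between them can now be assigned to a single change, methyl in place of hydrogen on a nitrogen on an aromatic ring, which gives a 19-fold higher number from compound 1 to compound 4 (1.28 log units; beyond the scatter); no measurement here explains either result.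

Going by these compounds, only hydrogen and methyl appear on that nitrogen, so it remains open how an ethyl group or a longer chain there would compare. It is also open whether an amine or a carboxylic acid on the groups attached to the oxygen would stay as level as the neutral rings shown here, or whether hydrogen on the nitrogen would give the same gain alongside the other oxygen groups.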